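A few compounds are considered here, and "the series" means these few. Any claim that something is new, unique, unknown or untested is made for them only; others in the source may bear on it.

Going by the values given here, compound 3 `COc1cc(N)c(Cl)cc1C(=O)NC1CCN(CCCCCN2CCCCC2)CC1` gives 5.01 nM in a functional assay on HEK293 cells for agonist activity at 5-hydroxytryptamine receptor 4 (Homo sapiens), read by cAMP accumulation (on this read-out lower numbers stand for an effect already at smaller amounts and higher numbers for an effect only at larger amounts of compound), the lowest number of the three measured so far; compound 2 `COc1cc(N)c(Cl)cc1C(=O)NC1CCN(CCCCCO)CC1` gives 15.9 nM and compound 1 `CCCCCN1CCC(NC(=O)c2cc(Cl)c(N)cc2OC)CC1` gives 25.1 nM. Compound 4 `COc1cc(N)c(Cl)cc1C(=O)NC1CCN(CCCCCN2CCN(S(C)(=O)=O)CC2)CC1` carries 4-(methylsulfonyl)piperazin-1-yl in place of piperidin-1-yl on a saturated chain carbon, five bonds along the chain from an amine nitrogen in a ring. Among the compounds with values here, the steps that bear on this end of the chain are a 5.0-fold lower number from compound 1 to compound 3 (0.70 log units; beyond the scatter) and a 3.2-fold lower number from compound 2 to compound 3 (0.50 log units; beyond the scatter), both modest and beyond the scatter, while a 1.6-fold lower number from compound 1 to compound 2 (0.20 log units; within the scatter) lies within it. Within the data shown here, no measured step exchanges one ring for another at this position, so the size of the change is open. The expected outcome for compound 4 is a small rise in number, a 2.0-fold higher number from compound 3 to compound 4 (0.30 log units; within the scatter), close to the scatter. Compound 4 is therefore estimated at 10 nM, in the range 3 nM to 40 nM.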

Compound 4, half-maximal effective concentration: 12.6 nM
Compound 4: the middle estimate sits 1.3-fold (0.10 log units) below what was measured; the measured number falls inside the stated range.
By their numbers in this assay, from the lowest: compound 3; then compounds 4, 2 and 1 (each within the scatter of the next).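

In this assay, going by these compounds alone, the first exchange of one ring for another at this chain end gives a 2.5-fold higher number from compound 3 to compound 4 (0.40 log units; beyond the scatter), so this position responds to the change from piperidin-1-yl to 4-(methylsulfonyl)piperazin-1-yl. The larger ring no longer separates clearly from the smaller ends, with a 1.3-fold lower number from compound 2 to compound 4 (0.10 log units; within the scatter) and a 2.0-fold lower number from compound 1 to compound 4 (0.30 log units; within the scatter) both within the scatter. Nothing measured here explains the step.

Still open, from the compounds shown here alone, is whether the step follows the methylsulfonyl group or the second ring nitrogen. A morpholine ring or an acetyl-bearing piperazine at this chain end would help separate the two.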